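The source may hold more compounds than are shown below. What is called first, only, known or untested is meant among the compounds shown, and "the series" means these compounds.

Compound 3 `CCc1nc(N)c2nc(O)n(Cc3ccccc3)c2n1` gives 3 mg/kg in a functional assay on the whole organism for activation, with Mus musculus as the target (a lower number here means that less compound is needed, a higher number that more compound is needed for the effect), the highest number of the three measured compounds; compound 2 `CCCCCOc1nc(N)c2nc(O)n(Cc3ccccc3)c2n1` gives 0.3 mg/kg and compound 1 `CCSc1nc(N)c2nc(O)n(Cc3ccccc3)c2n1` gives 0.1 mg/kg in this assay . Compound 4 `CCCOc1nc(N)c2nc(O)n(Cc3ccccc3)c2n1` carries the change (propoxy in place of ethyl on an aromatic carbon), on the aromatic carbon between two ring nitrogen atoms. The measured step that bears most directly on this change runs the other way, as a 10-fold higher number from compound 2 to compound 3 (1.00 log units; beyond the scatter), and putting a chain with a heteroatom in place of ethyl also matches a 30-fold higher number from compound 1 to compound 3 (1.48 log units; beyond the scatter), while a 3.0-fold higher number from compound 1 to compound 2 (0.48 log units; beyond the scatter) shows the pentyloxy compound sitting above the ethylsulfanyl one. Propoxy in place of ethyl is therefore expected to lower the number for compound 4, an estimated step of a 7.5-fold lower number from compound 3 to compound 4 (0.88 log units; beyond the scatter). Compound 4 is expected to give 0.4 mg/kg, within a range of 0.12 mg/kg to 1.2 mg/kg.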

Compound 4, minimum effective dose: 0.3 mg/kg
Beside the measured number, compound 4's estimate is 1.3-fold (0.12 log units) above it; measured number inside the range.
By their numbers in this assay, from the lowest: compound 1; then compounds 2 and 4 (each within the scatter of the next); then compound 3.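

In this assay, propoxy in place of ethyl on the aromatic carbon between two ring nitrogen atoms gives a 10-fold lower number from compound 3 to compound 4 (1.00 log units; beyond the scatter), so the gap seen earlier with pentyloxy also appears with a shorter oxygen-linked chain. Propoxy and pentyloxy are not separated here, with no change at the digits printed from compound 2 to compound 4 (within the scatter). Ethylsulfanyl keeps its lead over propoxy, with a 3.0-fold higher number from compound 1 to compound 4 (0.48 log units; beyond the scatter).

From the compounds shown here alone, whether propylsulfanyl, an amine or a chain longer than pentyloxy at this carbon would follow the same order remains open. Nothing available explains why these steps occur.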